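A few compounds are considered here, and "the series" means these few. Any claim that something is new, unique, unknown or untested is made for them only; others in the source may bear on it.

Compound 1, `Cc1ccc(-c2csc(NC(=O)COc3ccccc3)n2)cc1`, gives 50100 nM in a functional assay on Ehrlich cells (Mus musculus) for cytotoxicity, read by MTT assay, with a stated time of 48 h; on this read-out lower numbers stand for stronger inhibition and higher numbers for weaker inhibition.
Compound 2, `Cc1ccc(-c2csc(NC(=O)COc3ccccc3C)n2)cc1`, gives 54400 nM in this assay.
Compound 3, `O=C(COc1ccccc1)Nc1nc(-c2ccc(Br)cc2)cs1`, gives 37200 nM in this assay.

Compound 2 differs from compound 1 by methyl in place of hydrogen on an aromatic carbon, and in this assay this change produced a 1.1-fold higher number from compound 1 to compound 2 (0.04 log units; within the scatter). Compound 3 differs from compound 1 in its core by bromo in place of methyl on an aromatic carbon, a change that brought a 1.3-fold lower number from compound 1 to compound 3 (0.13 log units; within the scatter). Compound 4, `Cc1ccccc1OCC(=O)Nc1nc(-c2ccc(Br)cc2)cs1`, has not yet been measured in this assay; it differs from compound 3 by methyl in place of hydrogen on an aromatic carbon. This is the same change as that from compound 1 to compound 2, at a place described in the same words, and it occurs twice among these compounds. Among the measured compounds shown here, only one earlier example of it exists, and that step left the number essentially where it was. Compound 4 is therefore expected to show a 1.1-fold higher number from compound 3 to compound 4 (0.03 log units; within the scatter), because a 1.1-fold higher number from compound 1 to compound 2 (0.04 log units; within the scatter) was the outcome of the same change, and with a single precedent the range around this expectation is kept wide. Compound 4 is thus estimated at 40000 nM, with the expected value lying between 20000 nM and 80000 nM.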

Compound 4, half-maximal inhibitory concentration: 44900 nM
Compound 4: the middle estimate sits 1.1-fold (0.05 log units) below what was measured, within the range that was stated.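

In this assay the change from phenoxy to 2-methylphenoxy on the bromo core brought a 1.2-fold higher number from compound 3 to compound 4 (0.08 log units; within the scatter), and it matches its earlier example: the same change on two cores in this assay, a 1.1-fold higher number (0.04 log units; within the scatter) from compound 1 to compound 2 and a 1.2-fold higher number (0.08 log units; within the scatter) from compound 3 to compound 4, 1.1-fold (0.05 log units) apart, within the scatter of two such steps. Read on the 2-methylphenoxy compounds, bromo in place of methyl brought a 1.2-fold lower number from compound 2 to compound 4 (0.08 log units; within the scatter), and this step also matches its earlier example: the same change on two cores in this assay, a 1.3-fold lower number (0.13 log units; within the scatter) from compound 1 to compound 3 and a 1.2-fold lower number (0.08 log units; within the scatter) from compound 2 to compound 4, 1.1-fold (0.05 log units) apart, within the scatter of two such steps. Among the compounds shown here, the two changes therefore read alike on both cores, but every one of these steps lies within the scatter, so the series shows only that neither change moved the number measurably here, not that a real effect carries from one core to another.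

The compounds shown leave open whether a different group on the phenoxy ring, such as methoxy, an amine or a carboxylic acid, would shift the number beyond the scatter. They also leave open what a longer chain between the phenoxy oxygen and the amide carbonyl would do.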